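The source may hold more compounds than are shown below. What is called first, only, known or untested is meant among the compounds shown, and "the series" means these compounds.

Of the compounds shown here, three sharing one core have been tested in a functional assay on MDA-MB-231 cells (Homo sapiens) for inhibition, read by MTT assay, with a stated time of 72 h; on this read-out higher numbers stand for weaker inhibition and lower numbers for stronger inhibition. Compound 1 `C=CC(=O)Nc1cccc(NC(=O)CSc2nc(Nc3ccccc3F)c3ccccc3n2)c1` gives 18700 nM. Compound 2 `C=CC(=O)Nc1cccc(NC(=O)CSc2nc(Nc3cccc(Br)c3)c3ccccc3n2)c1` gives 19400 nM, and a 1.0-fold higher number from compound 1 to compound 2 (0.02 log units; within the scatter). Compound 3 `C=CC(=O)Nc1cccc(NC(=O)CSc2nc(Nc3cccc([N+](=O)[O-])c3)c3ccccc3n2)c1` reaches only the limit of the assay, > 50000 nM, so it sits at the limit of > 50000 nM in this assay, at which 1 of the 3 values shown sits. Compound 4 `C=CC(=O)Nc1cccc(NC(=O)CSc2nc(Nc3ccc(Cl)cc3)c3ccccc3n2)c1` has not been measured; it differs from compound 3 by 4-chlorophenyl in place of 3-nitrophenyl on a nitrogen on an aromatic ring. Since the steps of an at least 2.6-fold higher number from compound 1 to compound 3 (0.42 log units; beyond the scatter) and an at least 2.5-fold higher number from compound 2 to compound 3 (0.41 log units; beyond the scatter) both ran toward weaker inhibition when a 3-nitrophenyl came in, and since a 1.0-fold higher number from compound 1 to compound 2 (0.02 log units; within the scatter) showed two halogen-bearing phenyls close together, compound 4 is expected to move back toward the numbers of compounds 1 and 2, a step of an at least 2.5-fold lower number from compound 3 to compound 4 (0.39 log units; beyond the scatter). Compound 4 is therefore expected near 20000 nM, within 9000 nM to 50000 nM.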

Compound 4, half-maximal inhibitory concentration: 10300 nM
For compound 4 the middle estimate is 1.9-fold (0.29 log units) above the measured one; low and high end bracket the measured number.
By their numbers in this assay, from the lowest: compounds 4, 1 and 2 (each within the scatter of the next). At a limit, above all of these: compound 3.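

In this assay, swapping 3-nitrophenyl for 4-chlorophenyl on this nitrogen restores measurable inhibition, an at least 4.8-fold lower number from compound 3 to compound 4 (0.68 log units; beyond the scatter). That step gives only a bound because compound 3 sits at a limit: the limit of > 50000 nM in this assay, at which 1 of the 4 values shown sits.

A third halogen-bearing phenyl also stays level with the other two, a 1.9-fold lower number from compound 2 to compound 4 (0.27 log units; within the scatter) and a 1.8-fold lower number from compound 1 to compound 4 (0.26 log units; within the scatter), so among the groups shown only 3-nitrophenyl stands apart.

On these data alone, this step changes both the substituent and its place on the ring, so their separate contributions remain open. Also open, as far as these compounds go, is how an amine or a carboxylic acid on this phenyl would behave.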